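This account rests on a few compounds, and the source may have more. Where it says the series, first, only, none or still open, it means among the compounds named here.

Compound 3 `O=S(=O)(c1ccc(F)c(Cl)c1)c1cnc2cc(F)ccc2c1-c1cccc(Cl)c1` gives 0.66 mL/min in an ADME assay on microsomes from liver (Homo sapiens) for metabolic stability, tested at 2.5 uM (a lower number here means slower removal, a higher number faster removal of the compound), which puts it second highest among the three numbers at hand. Compound 2 `N#Cc1cccc(S(=O)(=O)c2cnc3cc(F)ccc3c2-c2cccc(Cl)c2)c1` gives 0.99 mL/min, and the step of a 1.5-fold lower number from compound 2 to compound 3 (0.18 log units; within the scatter) lies within the scatter. Among the compounds with values here, compound 1 `O=S(=O)(c1cc(Cl)cc(Cl)c1)c1cnc2cc(F)ccc2c1-c1ccc(Cl)cc1` gives 0.13 mL/min, a number well below that of compound 3, but compound 1 differs from compound 3 in two places, so no single step is drawn between them.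

Compound 4 `O=S(=O)(c1cc(Cl)cc(Cl)c1)c1cnc2cc(F)ccc2c1-c1cccc(Cl)c1` differs from compound 3 in one place: 3,5-dichlorophenyl in place of 3-chloro-4-fluorophenyl on a sulfonyl sulfur. Within the data shown here, the only measured step at the sulfonyl sulfur, from compound 2 to compound 3, was small, and compound 1 shows that the shared core carrying a 3,5-dichlorophenyl on the sulfonyl sulfur can give a low number. The step from compound 3 to compound 4 is therefore expected to be a modest move to a lower number, a 2.1-fold lower number from compound 3 to compound 4 (0.31 log units; beyond the scatter), though it could stay within the scatter. Compound 4 is estimated to give 0.32 mL/min in this assay, with a range from 0.13 mL/min to 0.75 mL/min.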

Compound 4, intrinsic clearance in a liver preparation (reported as CLH), per the amount of preparation that the assay uses: 0.93 mL/min
The estimate for compound 4 lay 2.9-fold (0.46 log units) below the measured number, and the stated range ends below it.
By their numbers in this assay, from the lowest: compound 1; then compounds 3, 4 and 2 (each within the scatter of the next).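

In this assay, the sulfonyl sulfur has so far shown little sensitivity to the group it carries with 3-chlorophenyl on the shared core: the change to 3,5-dichlorophenyl gives a 1.4-fold higher number from compound 3 to compound 4 (0.15 log units; within the scatter) and a 1.1-fold lower number from compound 2 to compound 4 (0.03 log units; within the scatter). Within the data shown here, the low number of compound 1 therefore does not follow from 3,5-dichlorophenyl alone, since 3-chlorophenyl in place of 4-chlorophenyl on an aromatic carbon gives a 7.2-fold higher number from compound 1 to compound 4 (0.85 log units; beyond the scatter), the only one of these steps beyond the scatter. Nothing available explains this difference.

As far as these compounds go, only compound 1 carries 4-chlorophenyl, so it remains open whether that group would give a similarly low number alongside 3-cyanophenyl or 3-chloro-4-fluorophenyl on the sulfonyl sulfur. Also open, from the compounds shown here alone, is whether an amine or a carboxylic acid on the sulfonyl-bound ring would move the number beyond the scatter.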